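Swapping the group on a sulfur

The compounds below may be only part of what the source reports. "The series", "measured", "known", "first", "only" and "open" are said of these compounds alone.

Compound 1 `COc1ccc(SCc2ccc(C(=O)Nc3ccccc3N)cc2)cc1` reads 2570 nM
Compound 2 `Nc1ccccc1NC(=O)c1ccc(CSc2ccc(Cl)cc2)cc1` reads "not determined" (no result reported)

Both entries come from a functional assay on A549 cells (Homo sapiens) for antiproliferative activity, read by CCK-8 assay, with a stated time of 72 h (a higher number here means a weaker inhibitor, a lower number a stronger inhibitor), and cover compounds that share the same core. Compound 2 has no place on this scale: the entry for compound 2 is "not determined" (no result reported) and gives no single number. Compound 3 `Cc1cc(C)cc(SCc2ccc(C(=O)Nc3ccccc3N)cc2)c1` has yet to be measured. The change 3,5-dimethylphenyl in place of 4-chlorophenyl on a sulfur puts 3,5-dimethylphenyl in place of 4-chlorophenyl on a sulfur, while the rest of the structure stays the same.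

With no number for compound 2, this step has no starting value, so neither its size nor its direction can be read from the data. Going by the values given here, the only available guide is compound 1 at 2570 nM in this assay and a single number shows no trend. Compound 3 is therefore expected to differ from compound 1 by no more than the usual scatter, although the uncertainty is wide. The estimated value for compound 3 is 3000 nM with an expected range from 1000 nM to 9000 nM once measured.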

Compound 3, half-maximal inhibitory concentration: 2890 nM
For compound 3 the middle estimate is 1.0-fold (0.02 log units) above the measured one, and the stated range covers the measured number.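

Going by these compounds alone, this result gives the first pair on this sulfur that can actually be compared in this assay: a 1.1-fold higher number from compound 1 to compound 3 (0.05 log units; within the scatter). The two compounds cannot be told apart in this assay, so this one swap of one aromatic ring of carbon for another leaves the reading within what repeat measurements would give. Compound 2 has no number, so the step from it to compound 3 cannot be read and 4-chlorophenyl remains unplaced on this scale, while no measurement of any property of these groups is at hand to accompany the result.

Both groups with numbers are six-membered aromatic rings of carbon only, and one comparable pair is too little to establish a pattern for this position. The compounds shown leave open how the reading would respond to a quite different group on the sulfur, such as a saturated cyclohexyl ring, a pyridine ring, or a phenyl ring carrying a carboxylic acid or an amine.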